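The compounds below may be only part of what the source reports. "The series", "measured", "known", "first", "only" and "open" are said of these compounds alone.

Compound 1 `Cc1cc(N2CC[C@@H](C)[C@@H](N(C)c3ncnc4[nH]ccc34)C2)n2nc(SCc3nc4ccccc4[nH]3)nc2n1` belongs to a small set of three analogues that share one core and differ only in the group carried on a saturated chain carbon bound to a sulfur. In a functional assay on MGC-803 cells (Homo sapiens) for inhibition, read by MTT assay, with a stated time of 72 h (on this read-out lower numbers stand for stronger inhibition and higher numbers for weaker inhibition), compound 1 gives 21200 nM, which places it second highest of the three numbers: compound 2 `Cc1cc(N2CC[C@@H](C)[C@@H](N(C)c3ncnc4[nH]ccc34)C2)n2nc(SCc3ccc([N+](=O)[O-])cc3)nc2n1` gives 27000 nM, a difference that is a 1.3-fold higher number from compound 1 to compound 2 (0.11 log units; within the scatter), while compound 3 `Cc1cc(N2CC[C@@H](C)[C@@H](N(C)c3ncnc4[nH]ccc34)C2)n2nc(SCc3ccc(C(F)(F)F)cc3)nc2n1` gives 2680 nM, a difference that is a 7.9-fold lower number from compound 1 to compound 3 (0.90 log units; beyond the scatter). Between those two, a 10-fold lower number from compound 2 to compound 3 (1.00 log units; beyond the scatter).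

Compound 4 `Cc1cc(N2CC[C@@H](C)[C@@H](N(C)c3ncnc4[nH]ccc34)C2)n2nc(SCCCc3ccccc3)nc2n1` has not been measured in this assay. Relative to compound 1, the change is phenethyl in place of 1H-benzimidazol-2-yl on a saturated chain carbon bound to a sulfur. The two measured steps from compound 1 both exchange the 1H-benzimidazol-2-yl for a substituted phenyl, and they run from no change beyond the scatter to a modest lower number. Neither introduces a phenethyl, so the bearing is indirect, and a step of similar or smaller size toward a lower number is expected. Compound 4 is therefore estimated at 10000 nM, with a range from 3000 nM to 35000 nM, which corresponds to an expected 2.1-fold lower number from compound 1 to compound 4 (0.33 log units; beyond the scatter).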

Compound 4, half-maximal inhibitory concentration: > 100000 nM
Compound 4 was reported as a limit (the forecaster's own chance of this, stated with the estimate: 10%); middle value at least 10-fold (1.00 log units) from the limit.
By their numbers in this assay, from the lowest: compound 3; then compounds 1 and 2 (each within the scatter of the next). At a limit, above all of these: compound 4.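

Compound 4 is reported in this assay only as a limit: the limit of > 100000 nM in this assay, at which 1 of the 4 values shown sits.

The earlier compounds shown here showed changes at this position that stayed within the scatter or gave a lower number, whereas this change gives a higher one, with an at least 4.7-fold higher number from compound 1 to compound 4 (0.67 log units; beyond the scatter). The other two steps point the same way, with an at least 3.7-fold higher number from compound 2 to compound 4 (0.56 log units; beyond the scatter) and an at least 37-fold higher number from compound 3 to compound 4 (1.57 log units; beyond the scatter), so a phenyl ring in the group on the saturated chain carbon bound to a sulfur does not by itself keep the number in the range of compound 2 and compound 3.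

The compounds shown do not separate the effect of the longer chain from that of the unsubstituted ring in compound 4. A plain benzyl group, or a 3-phenylpropyl group with trifluoromethyl on its ring, would address that, and an amine or a carboxylic acid on the ring remains an open question.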